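The compounds below may be only part of what the source reports. "The series", "measured", "known", "first", "only" and "open" are said of these compounds alone.

Measured compounds, in a physicochemical assay for solubility, in phosphate buffer; on this read-out higher numbers stand for higher solubility and lower numbers for lower solubility:
- compound 1 `Cc1cc(N[C@H](CCCCNCc2ccccc2F)C(=O)NO)cc(C)c1F`: > 5 ug/mL, a limit
- compound 2 `COc1ccc(CNCCCC[C@@H](Nc2cc(C)c(F)c(C)c2)C(=O)NO)cc1`: > 5 ug/mL, a limit
- compound 3 `Cc1cc(N[C@H](CCCCNCc2ccc(C(F)(F)F)cc2)C(=O)NO)cc(C)c1F`: > 5 ug/mL, a limit

For compound 3, > 5 ug/mL is a limit and not a number. The position of compound 3 is shared by the other measured compounds: the limit of > 5 ug/mL in this assay, at which 3 of the 3 values shown sit.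

Compound 4 `Cc1cc(N[C@H](CCCCNCCCc2ccc(F)cc2)C(=O)NO)cc(C)c1F` carries 2-(4-fluorophenyl)ethyl in place of 4-(trifluoromethyl)phenyl on a saturated chain carbon bound to an amine nitrogen.

The closest measured changes at this place are a step that the two limits leave unreadable from compound 1 to compound 2 and a step that the two limits leave unreadable from compound 1 to compound 3. Neither gives a size to carry over, so no step beyond the scatter is expected in this assay. The expected change is a step that the limit leaves unreadable from compound 3 to compound 4. The estimate for compound 4 is 7 ug/mL, with an expected range of 3 ug/mL to 20 ug/mL.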

Compound 4, solubility: > 5 ug/mL
Compound 4 was reported as a limit (the forecaster's own chance of this, stated with the estimate: 75%); the middle value lies beyond the limit too.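

In this assay, among these compounds, compound 4 gives > 5 ug/mL, a limit, and no step to it from compound 1, compound 2 or compound 3 can be read. From the compounds shown here alone, how far any of these four compounds lies beyond the limit in this assay stays open, and with it whether the groups at this place differ at all.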